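This account rests on a few compounds, and the source may have more. Where it says the series, first, only, none or still open, it means among the compounds named here.

Compound 1 `Cc1c(OCCCCOc2ccccc2C(=O)O)ccc(C(=O)CC2CCCC2)c1C` was examined in an assay on HEK293 cells for positive allosteric modulation of metabotropic glutamate receptor 2 (Rattus norvegicus), read by thallium flux, with a stated time of 2.5 min (on this read-out lower numbers stand for an effect already at smaller amounts and higher numbers for an effect only at larger amounts of compound), where compound 1 gives 2580 nM. Among the three measured compounds this is the highest number. Its nearest neighbour is compound 3 `CCCC(=O)c1ccc(OCCCCOc2ccc(C(=O)O)cc2C)c(C)c1O`, which in this assay gives 104 nM; the gap between compound 3 and compound 1 lies beyond the scatter. Furthest away stands compound 2 `COc1cc(C(=O)O)ccc1OCCCCOc1ccc(C(=O)CC(C)C)c(O)c1C`, which in this assay gives 40 nM, again a gap to compound 1 that lies beyond the scatter. Both compound 2 and compound 3 carry a hydroxy group, whereas compound 1 carries none.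

The step of interest leads from compound 1 to compound 4 `Cc1c(OCCCCOc2ccccc2C(=O)O)ccc(C(=O)CC2CCCC2)c1O`. The change is hydroxy in place of methyl on an aromatic carbon. Among the compounds with values here, no measured pair shows this same change, so its size cannot be read off directly. Still, compound 2 with 40 nM and compound 3 with 104 nM both sit far below compound 1, and both carry the hydroxy group that enters here. A large step downward in this assay is therefore expected, well beyond the scatter. Compound 4 is expected to give about 150 nM in this assay, with a range from 50 nM to 500 nM. The expected step is a 17-fold lower number from compound 1 to compound 4 (1.24 log units; beyond the scatter), an estimate that rests on the values of compound 2 and compound 3 alone.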

Compound 4, half-maximal effective concentration: 335 nM
The estimate for compound 4 lay 2.2-fold (0.35 log units) below the measured number, and the stated range covers the measured number.
By their numbers in this assay, from the lowest: compound 2; then compound 3; then compound 4; then compound 1.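

In this assay, hydroxy in place of methyl on this aromatic carbon, ortho to a (cyclopentylmethyl)carbonyl group and ortho to a methyl group, gives a 7.7-fold lower number from compound 1 to compound 4 (0.89 log units; beyond the scatter). Within the data shown here, the earlier compounds offered no pair differing in one place, so this is the first direct reading of the change: with the rest of the core of compound 1 held constant, exchanging this one methyl group for hydroxy, which adds a hydrogen-bond donor and a hydrogen-bond acceptor, moves the number beyond the scatter. The result shows that this position responds to the exchange, but nothing shown here explains the size or direction of the step.

On these data alone, it remains open whether hydroxy is special at this carbon or whether another group, such as an amine, a methoxy group or a fluorine atom, would give a comparable step. As far as these compounds go, it is also open whether the same exchange would produce a step of similar size with a shorter alkyl chain in place of the cyclopentylmethyl part of the (cyclopentylmethyl)carbonyl group, or with the carboxylic acid replaced by an amide.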